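Benzyl in Place of Phenyl on the Anilino Nitrogen

A few compounds are considered here, and "the series" means these few. Any claim that something is new, unique, unknown or untested is made for them only; others in the source may bear on it.

Compound 1 `CC1=C(C(=O)Nc2ccccc2Cl)C(c2cnc(CS)n2Nc2ccccc2)NC(=O)N1` was tested in an ADME assay on Vero cells (Chlorocebus sabaeus) for cytotoxicity, read by XTT assay, with a stated time of 72 h; on this read-out higher numbers stand for lower toxicity in this test and lower numbers for higher toxicity in this test. In this assay compound 1 gives > 100000 nM, which is a limit of the assay rather than a number. Compound 2 `CC1=C(C(=O)Nc2cccc(Cl)c2)C(c2cnc(CS)n2Nc2ccccc2)NC(=O)N1` gives 98600 nM in this assay. Compound 3 `CC1=C(C(=O)Nc2ccc(Cl)cc2)C(c2cnc(CS)n2Nc2ccccc2)NC(=O)N1` gives > 100000 nM in this assay, again a limit rather than a number. Compound 1 thus stands at the limit of > 100000 nM in this assay, at which 2 of the 3 values shown sit. The measured steps alter only the chlorophenyl on the amide-type nitrogen: an at least 1.0-fold lower number from compound 1 to compound 2 (0.00 log units; that floor lies within the scatter), an at least 1.0-fold higher number from compound 2 to compound 3 (0.00 log units; that floor lies within the scatter), and a step that the two limits leave unreadable from compound 1 to compound 3. Compound 4 `CC1=C(C(=O)Nc2ccccc2Cl)C(c2cnc(CS)n2NCc2ccccc2)NC(=O)N1` differs from compound 1 at another place: benzyl in place of phenyl on a nitrogen on an aromatic ring. Going by the values given here, no measured step touches this change, so the expectation rests on the level of the three values shown. Compound 4 is expected to remain at that level, a number no higher from compound 1 to compound 4 (the limit leaves the size open), with an estimate of 100000 nM in this assay, between 50000 nM and 200000 nM.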

Compound 4, half-maximal cytotoxic concentration: > 100000 nM
Compound 4 was reported as a limit; the forecaster's own chance of this, stated with the estimate: 65%; the middle value lies on the limit itself.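

In this assay compound 4 gives > 100000 nM, a limit and not a number. Going by these compounds alone, compound 1 also stands at a limit, so no step between compound 1 and compound 4 can be read. The compounds shown leave open what benzyl in place of phenyl does to the number.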